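Cytotoxicity notes: a methyl added to compound 2

This account rests on a few compounds, and the source may have more. Where it says the series, first, only, none or still open, it means among the compounds named here.

Measured so far:
compound 1 `CCC(=O)Oc1ccc2c(C)cc(=O)oc2c1Cc1c(-c2ccccc2)[nH]c2ccccc12` gives 38000 nM
compound 2 `CC(=O)Oc1ccc2ccc(=O)oc2c1Cc1c(-c2ccccc2)[nH]c2ccccc12` gives > 100000 nM

Both values come from an ADME assay on MT4 cells (Homo sapiens) for cytotoxicity, read by MTT assay, with a stated time of 96 h; a higher number here means that more compound is tolerated, a lower number that less compound is tolerated. The value of compound 2 is a limit of the assay and not a number. Compound 2 thus stands at the limit of > 100000 nM in this assay, at which 1 of the 2 values shown sits, while compound 1 gives a number, 38000 nM.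

Compound 3 `CC(=O)Oc1ccc2c(C)cc(=O)oc2c1Cc1c(-c2ccccc2)[nH]c2ccccc12` is yet to be measured in this assay. It differs from compound 2 by methyl in place of hydrogen on an aromatic carbon. Compound 1 carries the same methyl together with a propanoate ester in place of the acetate and is clearly less tolerated than the limit reached by compound 2.

Within the data shown here, no measured pair differing in one place is available, so the size of the step must be guessed. Because compound 2 sits at the limit of > 100000 nM in this assay, at which 1 of the 2 values shown sits, a downward step of uncertain size is expected, in the direction of less compound tolerated. The step from compound 2 to compound 3 is estimated as an at least 1.6-fold lower number from compound 2 to compound 3 (0.22 log units; that floor lies within the scatter). For compound 3 the expected value in this assay is 60000 nM, with a range from 25000 nM to 150000 nM.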

Compound 3, half-maximal cytotoxic concentration: > 100000 nM
Compound 3: a limit, no number; the forecaster's own chance of this, stated with the estimate: 35%; middle value at least 1.6-fold (0.22 log units) away from the limit.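

In this assay compound 3 gives > 100000 nM, which is a limit of the assay and not a number. The methyl on the aromatic carbon opposite the ring oxygen therefore does not by itself bring the acetate down to a measurable value, but the step it makes cannot be read, as both ends of that pair are limits: the limit of > 100000 nM in this assay, at which 2 of the 3 values shown sit.
Among these compounds, the one readable change lies at the ester and not on the aromatic ring: hydrogen in place of methyl on a saturated chain carbon bound to a carbonyl carbon, which turns the propanoate into the acetate, gives an at least 2.6-fold higher number from compound 1 to compound 3 (0.42 log units; beyond the scatter).

That step is only a floor, and any effect of the aromatic methyl stays out of view in this assay. Still open, on these data alone, is whether the propanoate needs the aromatic methyl to give a measurable value, and whether a longer chain such as a butanoate, or an amine in place of the ester, would lie further down in this assay.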